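Compound 1 to compound 4: a new carbonyl substituent

A few compounds are considered here, and "the series" means these few. Any claim that something is new, unique, unknown or untested is made for them only; others in the source may bear on it.

In an ADME assay on microsomes from liver (Mus musculus) for metabolic stability, read by LC-MS, using NADPH, with a stated time of 60 min, tested at 1 uM (on this read-out lower numbers stand for a shorter-lived compound and higher numbers for a longer-lived compound), compound 1 (`O=C(O)CC1Cc2ccc(-c3cc(F)cc(OC(F)F)c3)cc2N1S(=O)(=O)c1cccc(C(F)(F)F)c1`) gives 1.88 h as the highest of three numbers. Compound 2 (`O=C(O)CC1CN(S(=O)(=O)c2cccc(C(F)(F)F)c2)c2cc(-c3cc(F)cc(OC(F)F)c3)ccc21`) gives 0.76 h and compound 3 (`O=C(O)CCCC1CN(S(=O)(=O)c2cccc(C(F)(F)F)c2)c2cc(-c3cc(F)cc(OC(F)F)c3)ccc21`) gives 0.57 h and both lie lower than compound 1 beyond the scatter. Compound 4 (`O=C(CC1Cc2ccc(-c3cc(F)cc(OC(F)F)c3)cc2N1S(=O)(=O)c1cccc(C(F)(F)F)c1)N1CCC(O)CC1`) carries 4-hydroxypiperidin-1-yl in place of hydroxy on a carbonyl carbon. Within the data shown here, the one measured step (a 1.3-fold lower number from compound 2 to compound 3 (0.12 log units; within the scatter)) keeps the carboxy group and so bears only weakly on this change. Among the measured compounds shown here, no measured compound lacks that group. For compound 1 a fall is expected because compound 1 with 1.88 h stands at the top of the set. The expected step is a 2.4-fold lower number from compound 1 to compound 4 (0.37 log units; beyond the scatter) with wide uncertainty. Compound 4 is estimated at 0.8 h with an expected range from 0.3 h to 2 h in this series.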

Compound 4, half-life: 0.0117 h
Compound 4: the middle estimate sits 68-fold (1.83 log units) above what was measured; the measured number lies below the stated range.
By their numbers in this assay, from the lowest: compound 4; then compounds 3 and 2 (each within the scatter of the next); then compound 1.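

In this assay, 4-hydroxypiperidin-1-yl in place of hydroxy on the carbonyl carbon gives a 160-fold lower number from compound 1 to compound 4 (2.21 log units; beyond the scatter), so this position responds far more strongly than the chain change of a 1.3-fold lower number from compound 2 to compound 3 (0.12 log units; within the scatter) suggested. The carboxy group of compound 1 cannot be exchanged for (4-hydroxypiperidin-1-yl)carbonyl here without a large loss of half-life. No measurement at hand accounts for the size of this fall.

Still open, on these data alone, is whether any replacement of hydroxy at this carbonyl carbon has this effect, or only this one. A primary amide, a piperidine lacking the hydroxy, or a methyl ester would separate these cases.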